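Swapping the Aryl Group: Expected Solubility of Compound 4

This account rests on a few compounds, and the source may have more. Where it says the series, first, only, none or still open, it means among the compounds named here.

Compound 1 `Cc1ccccc1-c1nc(CN2CCC(C(=O)NCCCN3CCC(C(C)C)CC3)CC2)c(C)o1` gives > 71 ug/mL, a limit of the assay.
Compound 2 `Cc1oc(-c2c(F)cccc2F)nc1CN1CCC(C(=O)NCCCN2C[C@H](C)C[C@H](C)C2)CC1` gives > 72 ug/mL, a limit of the assay.
Compound 3 `Cc1ccccc1-c1nc(CN2CCC(C(=O)NCCN3C[C@H](C)C[C@H](C)C3)CC2)c(C)o1` gives > 67 ug/mL, a limit of the assay.

In a physicochemical assay for solubility, in phosphate buffer, measured as kinetic solubility, at pH 7.4 (a higher number here means a more soluble compound, a lower number a less soluble compound), compound 2 stands at a limit rather than at a number. Among the compounds with values here, the other two compounds also stand at limits, as the limit of > 67 ug/mL in this assay, at which 1 of the 3 values shown sits, and the limit of > 71 ug/mL in this assay, at which 1 of the 3 values shown sits, show, so no compound can be placed above or below another. Within the data shown here, the only step between measured compounds, a step that the two limits leave unreadable from compound 1 to compound 3, changes a different part of the molecule, and its size is not readable; both of its ends are limits.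

Compound 4 `Cc1cc(C)cc(-c2nc(CN3CCC(C(=O)NCCCN4C[C@H](C)C[C@H](C)C4)CC3)c(C)o2)c1` is reached from compound 2 by 3,5-dimethylphenyl in place of 2,6-difluorophenyl on an aromatic carbon. Among the measured compounds shown here, no measured step touches this position, so there is no direct evidence on how the change affects solubility. What the three measured compounds show is that the whole series, with three different aromatic groups at this position, sits at the upper limit, and compound 1 with its 2-methylphenyl group is among them, per (the limit of > 71 ug/mL in this assay, at which 1 of the 3 values shown sits).

On that basis compound 4 is expected to show a step of an at least 1.1-fold lower number from compound 2 to compound 4 (0.04 log units; that floor lies within the scatter), no more than the scatter. Compound 4 is therefore estimated at 65 ug/mL, between 20 ug/mL and 150 ug/mL, most likely again reported as a limit.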

Compound 4, solubility: > 71 ug/mL
Compound 4 gave a limit, no number; the forecaster's own chance of this, stated with the estimate: 55%; at least 1.0-fold (0.03 log units) between middle value and limit.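

In this assay compound 4 gives > 71 ug/mL, a limit of the assay. Compound 2 gives > 72 ug/mL, also a limit, so no step can be read between compound 2 and compound 4. The compounds shown leave open what the actual solubility of each compound is, and whether exchanging 2,6-difluorophenyl for 3,5-dimethylphenyl changes it at all.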